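Phenyl substitution in a receptor binding series

The source may hold more compounds than are shown below. What is called first, only, known or untested is meant among the compounds shown, and "the series" means these compounds.

Compound 3 `O=C(O)CCCCCOc1cc(-c2ccccc2)cc(-c2ccccc2)n1` gives 3 nM in an assay on cell membranes from spleen (Cavia porcellus) for binding affinity to leukotriene B4 receptor 1 (Homo sapiens) (a higher number here means a weaker inhibitor, a lower number a stronger inhibitor), the lowest number among the three measured compounds. Compound 1 `O=C(O)CCCCCOc1cc(-c2ccccc2Cl)cc(-c2ccccc2)n1` carries chloro on an aromatic carbon of that phenyl and gives 200 nM in this assay; compound 2 `COc1ccc(-c2cc(-c3ccccc3)cc(OCCCCCC(=O)O)n2)cc1` carries methoxy and gives 1000 nM in this assay. Removing these groups gives a 67-fold lower number from compound 1 to compound 3 (1.82 log units; beyond the scatter) and a 330-fold lower number from compound 2 to compound 3 (2.52 log units; beyond the scatter), so each substituent so far examined on this phenyl weakens binding well beyond the scatter.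

Compound 4 `O=C(O)CCCCCOc1cc(-c2ccc(C(F)(F)F)cc2)cc(-c2ccccc2)n1` has not been measured in this assay. Its difference from compound 3 is trifluoromethyl in place of hydrogen on an aromatic carbon: the group enters on an aromatic carbon of a six-membered aromatic ring of carbon only, para to a large group, so phenyl becomes 4-(trifluoromethyl)phenyl. Both relevant steps were large losses, and a large upward step a 100-fold higher number from compound 3 to compound 4 (2.00 log units; beyond the scatter) is expected for compound 4 because of a 330-fold lower number from compound 2 to compound 3 (2.52 log units; beyond the scatter) and a 67-fold lower number from compound 1 to compound 3 (1.82 log units; beyond the scatter) in compound 2 and compound 1. Compound 4 is therefore estimated at 300 nM, with a range from 50 nM to 2000 nM.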

Compound 4, half-maximal inhibitory concentration: 10 nM
Compound 4: middle estimate off by 30-fold (1.48 log units), on the high side, outside the stated range (below it).
By their numbers in this assay, from the lowest: compound 3; then compound 4; then compound 1; then compound 2.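

In this assay, trifluoromethyl on this phenyl still weakens binding, but only by a 3.3-fold higher number from compound 3 to compound 4 (0.52 log units; beyond the scatter), so a substituent on this ring need not bring a large loss. Replacing 2-chlorophenyl with 4-(trifluoromethyl)phenyl gives a 20-fold lower number from compound 1 to compound 4 (1.30 log units; beyond the scatter), which shows that the outcome on this ring depends strongly on what is attached and where, although this step changes both group and place and cannot separate the two. No measurement is available that bears on the reason for these differences.

On these data alone, it remains open whether chloro on the aromatic carbon that holds trifluoromethyl in compound 4 would match that group or stay closer to compound 1. Also open, as far as these compounds go, is how an amine or a carboxylic acid on that same carbon would compare with compound 3.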